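Urea side chains on a quinolinyl oxadiazolyl piperidine core

The source may report more compounds than this note shows. Statements on the series, on what has been measured and on what is new or still open speak of the compounds shown alone.

Measured so far:
Compound 1, `Cc1noc(C)c1NC(=O)N1CCC(c2nc(-c3ccc4ccccc4n3)no2)CC1`: 3000 nM
Compound 2, `N#Cc1ccccc1NC(=O)N1CCC(c2nc(-c3ccc4ccccc4n3)no2)CC1`: 190 nM
Compound 3, `COc1ccccc1N(C)C(=O)N1CCC(c2nc(-c3ccc4ccccc4n3)no2)CC1`: 3100 nM

In a functional assay on Shh Light II cells (Mus musculus) for inhibition, read by a luciferase reporter (on this read-out lower numbers stand for stronger inhibition and higher numbers for weaker inhibition), compound 3 gives 3100 nM, the highest of the three numbers; its nearest neighbour is compound 1, with a step of a 1.0-fold higher number from compound 1 to compound 3 (0.01 log units; within the scatter), which is within the scatter, while the step of a 16-fold higher number from compound 2 to compound 3 (1.21 log units; beyond the scatter) is large and beyond it. Compound 4, `O=C(Nc1ncccc1Cl)N1CCC(c2nc(-c3ccc4ccccc4n3)no2)CC1`, differs from compound 3 by (3-chloropyridin-2-yl)amino in place of (2-methoxyphenyl)(methyl)amino on a carbonyl carbon. The step that bears most directly on this change is a 16-fold higher number from compound 2 to compound 3 (1.21 log units; beyond the scatter), since compound 4, like compound 2, carries a (3-chloropyridin-2-yl)amino type linkage without the methyl on the nitrogen and with a small substituent on the aromatic ring. The step of a 16-fold lower number from compound 1 to compound 2 (1.20 log units; beyond the scatter) shows that an aromatic amino group of this kind can give a much lower number than a 3,5-dimethyl-1,2-oxazol-4-yl one. Going by the values given here, no measured step, however, covers the chloropyridinyl group itself. Compound 4 is therefore expected to show a step of a 7.8-fold lower number from compound 3 to compound 4 (0.89 log units; beyond the scatter), a clearly lower number. The estimate for compound 4 is 400 nM, with a range from 100 nM to 1600 nM.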

Compound 4, half-maximal inhibitory concentration: 2800 nM
Compound 4: middle estimate off by 7.0-fold (0.85 log units), on the low side; measured number above the stated range.
By their numbers in this assay, from the lowest: compound 2; then compounds 4, 1 and 3 (each within the scatter of the next).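

In this assay, compound 4 regains the amide hydrogen that compound 3 lacks and swaps the 2-methoxyphenyl for a 3-chloropyridin-2-yl ring, yet the result is a 1.1-fold lower number from compound 3 to compound 4 (0.04 log units; within the scatter) and, against the other ring with an amide hydrogen, a 1.1-fold lower number from compound 1 to compound 4 (0.03 log units; within the scatter), so the side chains of compounds 1, 3 and 4 cannot be told apart here. A six-membered aromatic ring on the amide-type nitrogen is therefore not enough for a low number, as a 15-fold higher number from compound 2 to compound 4 (1.17 log units; beyond the scatter) shows, and among these four compounds only the 2-cyanophenyl urea of compound 2 stands apart. No measurement at hand accounts for this gap.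

From the compounds shown here alone, compound 4 differs from compound 2 in both the ring nitrogen and the chlorine in place of the nitrile, so it remains open which of the two goes with the higher number. A chlorophenyl or a cyanopyridinyl group on the same nitrogen would separate them.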